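Trimming an Acetyl from an Oxime Ester Side Group

The source may hold more compounds than are shown below. What is called first, only, known or untested is meant among the compounds shown, and "the series" means these compounds.

Measured in a functional assay, with a stated time of 30 min (on this read-out higher numbers stand for weaker inhibition and lower numbers for stronger inhibition), so far:
Compound 1, `COc1ccc(C2CC(=NO)CC(c3ccc(OC)cc3)N2C)cc1`: 380000 nM
Compound 2, `COc1ccc(C2CC(=NOC(=O)c3ccccc3OC(C)=O)CC(c3ccc(OC)cc3)N2C)cc1`: 350000 nM

Both numbers lie within the scatter of each other, so neither compound can be called the stronger inhibitor. Going by the values given here, the only step in hand, a 1.1-fold lower number from compound 1 to compound 2 (0.04 log units; within the scatter), came from placing a (2-acetoxyphenyl)carbonyl group on an oxygen in place of hydrogen, and that whole addition left the read-out essentially unchanged.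

Compound 3, `COc1ccc(C2CC(=NOC(=O)c3ccccc3O)CC(c3ccc(OC)cc3)N2C)cc1`, differs from compound 2 by a smaller edit: hydrogen in place of acetyl on an oxygen on an aromatic ring. Among the compounds with values here, no measured step follows this exact change, so the expectation rests on the one step available. Since adding the entire (2-acetoxyphenyl)carbonyl group moved the number only by a 1.1-fold lower number from compound 1 to compound 2 (0.04 log units; within the scatter), removing just its acetyl is expected to move it little as well, and the step of no change at the digits printed from compound 2 to compound 3 (within the scatter) is expected to remain within the scatter. Compound 3 is therefore estimated at about 350000 nM, with a range from 150000 nM to 800000 nM.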

Compound 3, half-maximal inhibitory concentration: 29000 nM
Compound 3: middle estimate off by 12-fold (1.08 log units), on the high side; measured number outside the range, below it.
By their numbers in this assay, from the lowest: compound 3; then compounds 2 and 1 (each within the scatter of the next).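

Swapping acetyl for hydrogen on the oxygen on the aromatic ring gives a 12-fold lower number from compound 2 to compound 3 (1.08 log units; beyond the scatter) in this assay, so this small edit at the far end of the side group has a large effect on the read-out. Replacing hydrogen on the other oxygen with (2-hydroxyphenyl)carbonyl gives a 13-fold lower number from compound 1 to compound 3 (1.12 log units; beyond the scatter), while the (2-acetoxyphenyl)carbonyl group gave only a 1.1-fold lower number from compound 1 to compound 2 (0.04 log units; within the scatter), so whether the added side group changes the number at all depends on what sits on its aromatic oxygen. Nothing available here accounts for the size of this change.

On these data alone, with only acetoxy and hydroxy compared at this place, it remains open whether a methoxy or an amino group there would track compound 3 or compound 2. Also open, as far as these compounds go, is whether the hydroxy group is needed at all, which a plain benzoyl group, with hydrogen on the ring in place of hydroxy, would show when set against compound 3.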